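Compound 3 with 3-bromophenyl in place of 2-fluorophenyl

The source may report more compounds than this note shows. Statements on the series, on what has been measured and on what is new or still open speak of the compounds shown alone.

In a functional assay on A-375 cells (Homo sapiens) for cytotoxicity, read by CCK-8 assay, with a stated time of 24 h (a lower number here means a stronger inhibitor, a higher number a weaker inhibitor), compound 3 `COc1ccccc1Oc1c(N)nc(-c2ccccc2F)nc1OCCO` gives > 80000 nM, which is a limit and not a number. Compound 1 `COc1ccccc1Oc1c(N)nc(-c2ccccc2F)nc1Cl` gives > 80000 nM, also a limit. Compound 4 `COc1ccccc1Oc1c(N)nc(-c2cccc(Br)c2)nc1OCCO` carries 3-bromophenyl in place of 2-fluorophenyl on an aromatic carbon. The closest measured change leads to compound 2 `COc1ccccc1Oc1c(N)nc(-c2cccc(I)c2)nc1Cl`, which gives 2200 nM. There, 3-iodophenyl in place of 2-fluorophenyl produced an at least 36-fold lower number from compound 1 to compound 2 (1.56 log units; beyond the scatter), a large step. Going by these compounds, putting 2-hydroxyethoxy in place of chloro produced a step that the two limits leave unreadable from compound 1 to compound 3, so that group's contribution stays unknown. A large step to a lower number is therefore expected, though bromine replaces iodine here. The step is expected to be an at least 11-fold lower number from compound 3 to compound 4 (1.05 log units; beyond the scatter). Compound 4 is estimated at 7000 nM, with an expected range of 2000 nM to 40000 nM.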

Compound 4, half-maximal inhibitory concentration: 650 nM
Compound 4: middle estimate off by 11-fold (1.03 log units), on the high side; measured number outside the range, below it.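

On the 2-hydroxyethoxy compounds, 3-bromophenyl in place of 2-fluorophenyl gives an at least 120-fold lower number from compound 3 to compound 4 (2.09 log units; beyond the scatter) in this assay. The gain at this position therefore does not depend on iodine or on the chloro group, as compounds 1 and 2 alone left possible. The value of compound 3 is a limit and not a number, so the size of this step is only a bound: the limit of > 80000 nM in this assay, at which 2 of the 4 values shown sit.

The compounds shown do not separate the halogen from its position on the ring; a 3-fluorophenyl or a 2-bromophenyl group would tell these apart. Going by these compounds, how an amine or a longer chain would read in place of 2-hydroxyethoxy also stays open.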